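Replacing one triple bond with a double bond in compound 2

A few compounds are considered here, and "the series" means these few. Any claim that something is new, unique, unknown or untested is made for them only; others in the source may bear on it.

Within the data shown here, compound 2 `C[C@H](O)C#CC#CC#CC#CCCCCCCCC(=O)O` is the only compound with a full number in a functional assay on Col2 cells (Homo sapiens) for cytotoxicity; on this read-out lower numbers stand for an effect already at smaller amounts and higher numbers for an effect only at larger amounts of compound: compound 2 gives 5.5 ug/mL. The other measured compound, compound 1 `O=C(O)CCCCCCCC#CC#CC#CC#C[C@@H](O)CO`, does not reach a number. In this assay compound 1 gives > 20 ug/mL, which is a limit of the assay rather than a measured value. Among the measured compounds shown here, one end of the only measured step therefore sits at the limit of > 20 ug/mL in this assay, at which 1 of the 2 values shown sits. That step, an at least 3.6-fold lower number from compound 1 to compound 2 (0.56 log units; beyond the scatter), concerns a hydroxy on a saturated chain carbon, two bonds along the chain from an oxygen on a saturated carbon and a triple-bonded carbon. Compound 3 `C[C@H](O)/C=C/C#CC#CC#CCCCCCCCC(=O)O` differs from compound 2 in another place: 3-hydroxybut-1-en-1-yl in place of 3-hydroxybut-1-yn-1-yl on a triple-bonded carbon. For the measured compounds named here, no measured step touches a change of that kind, so the size of the step in this assay cannot be read from compound 1 and compound 2. The expectation is a step within the scatter, a 1.1-fold higher number from compound 2 to compound 3 (0.04 log units; within the scatter). Compound 3 is accordingly estimated at 6 ug/mL, with a range from 2.5 ug/mL to 15 ug/mL.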

Compound 3, concentration for half-maximal effect: 9.9 ug/mL
Estimate against measurement, compound 3: 1.7-fold (0.22 log units) below, and the stated range covers the measured number.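

Among these compounds, the earlier compounds spoke only to a hydroxy group on the saturated part of the chain, whereas compound 3 is the first to test the triple bond itself, on a triple-bonded carbon. In this assay, 3-hydroxybut-1-en-1-yl in place of 3-hydroxybut-1-yn-1-yl gives a 1.8-fold higher number from compound 2 to compound 3 (0.26 log units; within the scatter), so this pair shows no real change in the read-out when a double bond takes the place of that triple bond. The comparison with the dihydroxy compound, which changes the bond and the hydroxy groups in one move, is an at least 2.0-fold lower number from compound 1 to compound 3 (0.30 log units; that floor lies within the scatter), and it gives no firm separation. The value for compound 1 is a limit of the assay, not a number: the limit of > 20 ug/mL in this assay, at which 1 of the 3 values shown sits.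

From the compounds shown here alone, whether the read-out would hold with a fully saturated 3-hydroxybutyl group at this place remains open, as does the effect of an amine in place of the hydroxy group. The compounds shown also leave open what a methyl ester in place of the carboxylic acid would do.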